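The compounds below may be only part of what the source reports. "The series", "measured", "known", "first", "only" and "open" are said of these compounds alone.

Measured so far in a functional assay on HEL cells (Homo sapiens); a lower number here means that less compound is tolerated, a higher number that more compound is tolerated:
Compound 1 `O=C1c2ccccc2NS(=O)(=O)N1COCCO` gives 160 ug/mL.
Compound 2 `O=C1c2ccccc2NS(=O)(=O)N1Cc1ccccc1` gives only a limit, > 50 ug/mL.
Compound 3 `CCCOCN1c2ccccc2C(=O)NS1(=O)=O` likewise gives only a limit, > 50 ug/mL.

Among the compounds with values here, compound 1 is thus the only compound of the three with a number in this assay; the other two sit at the limit of > 50 ug/mL in this assay, at which 2 of the 3 values shown sit. Within the data shown here, the one step between measured compounds that differ in a single place, a step that the limit leaves unreadable from compound 1 to compound 2, cannot be read, since the value of compound 2 is a limit.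

Compound 4 `O=C1c2ccccc2NS(=O)(=O)N1COCc1ccccc1` differs from compound 1 by phenyl in place of hydroxymethyl on a saturated chain carbon bound to an oxygen on a saturated carbon. This change resembles the unreadable step from compound 1 to compound 2 in that a phenyl enters, but there the phenyl replaced the whole 2-hydroxyethoxy group, whereas here the hydroxymethyl alone leaves. Among the measured compounds shown here, no measured step therefore gives the size of what to expect in this assay, in either direction, beyond the scatter.

Compound 4 is estimated at 110 ug/mL, between 40 ug/mL and 250 ug/mL, and the estimated step of a 1.5-fold lower number from compound 1 to compound 4 (0.16 log units; within the scatter) is taken as near zero; a limit rather than a number is quite possible.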

Compound 4, half-maximal cytotoxic concentration: 148 ug/mL
For compound 4 the middle estimate is 1.3-fold (0.13 log units) below the measured one, and the stated range covers the measured number.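

In this assay, within the data shown here, phenyl in place of hydroxymethyl on a saturated chain carbon bound to an oxygen on a saturated carbon gives a 1.1-fold lower number from compound 1 to compound 4 (0.03 log units; within the scatter), the first step at this position that can be read. The hydroxymethyl of compound 1 can thus be exchanged for a six-membered aromatic ring of carbon only, with a step that stays within the scatter of this cell measurement. Among these compounds, the earlier compounds could not show this, as the only step among them, from compound 1 to compound 2, cannot be read.

The entries for compound 2 and compound 3 remain limits and not numbers: the limit of > 50 ug/mL in this assay, at which 2 of the 4 values shown sit. Going by these compounds, what an amine, a carboxylic acid or a longer chain at this place would give in this assay stays open, and one step sets no pattern.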